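Adding a phenyl to an adenosine receptor binder

The compounds below may be only part of what the source reports. "The series", "measured", "known", "first", "only" and "open" are said of these compounds alone.

Measured compounds, with their results in an assay on CHO cells for displacement of a labelled ligand from adenosine receptor A1 (Homo sapiens), tested at 10 uM; on this read-out higher numbers stand for more inhibition at the one concentration tested (going by the name of the read-out) and lower numbers for less inhibition:
- compound 1 `O=C1CCCc2[nH]c(=O)c(C(=O)c3ccccc3)cc21` gives "not determined" (no result reported)
- compound 2 `O=C1CC(c2ccccc2)Cc2[nH]c(=O)c(C(=O)c3ccccc3)cc21` gives 5%
- compound 3 `CC(C)(C)C(=O)c1cc2c([nH]c1=O)CCCC2=O` gives 0%

Compound 3 has the smaller of the two reported numbers, but its gap to compound 2 lies within the usual scatter, so the two cannot be told apart: both show essentially no displacement at the single concentration tested. Compound 4 `CC(C)(C)C(=O)c1cc2c([nH]c1=O)CC(c1ccccc1)CC2=O` differs from compound 3 by phenyl in place of hydrogen on a saturated ring carbon. Going by the values given here, the same kind of change separates compound 2 from compound 1, yet compound 1 carries no number, so no measured step exists for it. With compound 2 at 5% after such a phenyl, no movement beyond the scatter is expected; the estimated step of a number 3 percentage points higher from compound 3 to compound 4 (within the scatter) is small. Compound 4 is therefore expected to give 3%, within 0% to 15%.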

Compound 4, a percentage reported as inhibition, at one concentration (the size of the read-out at that concentration, not a potency): 11%
Compound 4: middle estimate off by 8 percentage points, on the low side, within the range that was stated.
By their numbers in this assay, from the lowest: compounds 3, 2 and 4 (each within the scatter of the next, the first and the last beyond it).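

In this assay, going by these compounds alone, phenyl in place of hydrogen on a saturated ring carbon gives a number 11 percentage points higher from compound 3 to compound 4 (beyond the scatter), the first measured step for this change and one that clears the usual scatter. Tert-butyl in place of phenyl on a carbonyl carbon gives a number 6 percentage points higher from compound 2 to compound 4 (within the scatter), so these two groups cannot be told apart at that carbon. Nothing measured here gives a cause for either step.

As far as these compounds go, whether an amine or a carboxylic acid on the same saturated ring carbon would shift the inhibition remains open. So does whether a longer chain on the carbonyl carbon would separate from tert-butyl.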